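A few compounds are considered here, and "the series" means these few. Any claim that something is new, unique, unknown or untested is made for them only; others in the source may bear on it.

The compounds here are tested in an ADME assay on RAW264.7 cells (Mus musculus) for cytotoxicity, read by MTT assay; a higher number here means a weaker inhibitor, a lower number a stronger inhibitor. Compound 1 `COc1ccc(C(=O)/C=C/C=C/c2ccccc2)cc1` gives > 100000 nM, which is a limit of the assay and not a number. Compound 2 `COc1ccc(/C=C/C=C/C(=O)c2ccc(OC)cc2)cc1` offers no figure at all, as its result reads "not determined" (no result reported). The numbers for this small set therefore come down to the limit of > 100000 nM in this assay, at which 1 of the 2 values shown sits, and compound 2 has no place on the scale.

The next compound to be measured is compound 3 `COc1ccc(/C=C/C=C/C(=O)c2ccc(OC)c(O)c2)cc1`. The structural change is hydroxy in place of hydrogen on an aromatic carbon, with hydroxy in place of hydrogen on an aromatic carbon, ortho to a methoxy group and meta to a large group. Among the measured compounds shown here, no measured step shows what this change does, and without a number for compound 2, no step can be read from the data. The expectation leans on compound 1, whose > 100000 nM is again only a limit. A small step towards a lower number in this assay is expected, or none beyond the scatter, and the assay may again report only a limit. For compound 3 the estimated value is 80000 nM, with an expected range of 25000 nM to 150000 nM.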

Compound 3, half-maximal inhibitory concentration: 28400 nM
The estimate for compound 3 lay 2.8-fold (0.45 log units) above the measured number, within the range that was stated.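

Compound 3 gives 28400 nM in this assay, but no step can be read from this result: compound 2 has no number to compare with it, and compound 1 differs from it in more than one place. Compound 1 stands only at a limit: the limit of > 100000 nM in this assay, at which 1 of the 3 values shown sits.

On these data alone, what hydroxy in place of hydrogen on this aromatic carbon does to the number in this assay remains open.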